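The compounds below may be only part of what the source reports. "The series", "measured", "known", "first", "only" and "open" are said of these compounds alone.

Measured compounds in a functional assay on HepG2 cells (Homo sapiens) for cytotoxicity, read by MTT assay, with a stated time of 72 h; a higher number here means a weaker inhibitor, a lower number a stronger inhibitor: compound 1 `Cc1cc(=O)n(-c2ccccc2C(F)(F)F)nc1C(=O)Nc1ccc(Oc2ncnc3ccsc23)c(F)c1` gives 9380 nM; compound 2 `Cc1cc(=O)n(-c2ccccc2OC(F)(F)F)nc1C(=O)Nc1ccc(Oc2ncnc3ccsc23)c(F)c1` gives 15700 nM; compound 3 `Cc1cc(=O)n(-c2ccc(F)cc2)nc1C(=O)Nc1ccc(Oc2ncnc3ccsc23)c(F)c1` gives 470 nM.

Compound 3 stands as the strongest inhibitor of the three: the step of a 20-fold lower number from compound 1 to compound 3 (1.30 log units; beyond the scatter) and the step of a 33-fold lower number from compound 2 to compound 3 (1.52 log units; beyond the scatter) both lie well beyond the scatter. Compound 4 `Cc1cc(=O)n(-c2ccc(F)cc2)nc1C(=O)Nc1ccc(Oc2ncnc3sccc23)c(F)c1` keeps the whole of compound 3 except for one change, (a group of 9 heavy atoms (6 carbon, 2 nitrogen, 1 sulfur; one five-membered aromatic ring with 1 hetero atom, one six-membered aromatic ring with 2 hetero atoms) in place of a group of 9 heavy atoms (6 carbon, 2 nitrogen, 1 sulfur; one five-membered aromatic ring with 1 hetero atom, one six-membered aromatic ring with 2 hetero atoms), on an oxygen on an aromatic ring). Among the measured compounds shown here, none of the measured steps touches this part of the molecule; the steps from compound 1 and compound 2 concern the group on the aromatic nitrogen only, so nothing measured bears on the change. Compound 4 is therefore expected to stay close to compound 3 in this assay, with an estimated step of a 1.5-fold higher number from compound 3 to compound 4 (0.17 log units; within the scatter) that is unlikely to exceed the scatter. The estimate for compound 4 is 700 nM, in the range 250 nM to 2500 nM.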

Compound 4, half-maximal inhibitory concentration: 12500 nM
Compound 4: the middle estimate sits 18-fold (1.25 log units) below what was measured; measured number outside the range, above it.
By their numbers in this assay, from the lowest: compound 3; then compounds 1, 4 and 2 (each within the scatter of the next).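

In this assay, the group on the oxygen on an aromatic ring proved to matter: the same atoms joined differently, with identical ring and hydrogen-bond acceptor counts, gave a 27-fold higher number from compound 3 to compound 4 (1.42 log units; beyond the scatter) in a single change. Among the compounds shown here, until now, only the group on the aromatic nitrogen had been varied, so this is the first sign that the other end of the molecule also moves the number. Nothing measured here accounts for this step.

From the compounds shown here alone, whether the step would recur with 2-(trifluoromethyl)phenyl on the aromatic nitrogen remains open. So does the effect of adding an amine or a methoxy group to the group on the oxygen.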